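Four Amides Tested for Cytotoxicity in a Liver Cell Line

The source may report more compounds than this note shows. Statements on the series, on what has been measured and on what is new or still open speak of the compounds shown alone.

Measured compounds:
- Compound 1 `CCCCCCCCCCCCNC(=O)[C@@H](NC(=O)c1cc2ccccc2n1C)[C@@H](C)O` gives > 200000 nM in a functional assay on HepG2 cells (Homo sapiens) for cytotoxicity, read by MTT assay, with a stated time of 48 h (on this read-out higher numbers stand for weaker inhibition and lower numbers for stronger inhibition), a limit of the assay rather than a number.
- Compound 2 `CCCCCCCCCCCCNC(=O)[C@@H](NC(=O)/C=C/c1ccccc1)[C@@H](C)O` gives > 200000 nM in this assay, again a limit.
- Compound 3 `CCCCCCCCCCCCCCCCCCNC(=O)[C@@H](NC(=O)c1cc2ccccc2n1C)[C@@H](C)O` gives > 200000 nM in this assay, also a limit.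

Within the data shown here, all three measured compounds sit at the same edge of the assay, which is the only evidence on hand: the limit of > 200000 nM in this assay, at which 3 of the 3 values shown sit. Compound 2 arises from compound 1 by the change (2-phenylethenyl in place of 1-methyl-1H-indol-2-yl on a carbonyl carbon), and the step that the two limits leave unreadable from compound 1 to compound 2 cannot be read because both values are limits. Compound 3 arises from compound 1 by the change (hexyl in place of hydrogen on a saturated chain carbon, ten or more bonds along the chain from an amide-type nitrogen), and the step that the two limits leave unreadable from compound 1 to compound 3 is equally unreadable for the same reason: the limit of > 200000 nM in this assay, at which 3 of the 3 values shown sit.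

Compound 4 `CCCCCCCCCCCCCCCCCCNC(=O)[C@@H](NC(=O)/C=C/c1ccccc1)[C@@H](C)O` has not yet been measured. It arises from compound 3 by the change (2-phenylethenyl in place of 1-methyl-1H-indol-2-yl on a carbonyl carbon), the same change that turns compound 1 into compound 2, made here on the core of compound 3. The two cores differ as stated under the difference from compound 1 to compound 3, namely (hexyl in place of hydrogen on a saturated chain carbon, ten or more bonds along the chain from an amide-type nitrogen).

Among the measured compounds shown here, since no measured step here has a readable size, the expectation for compound 4 rests only on the shared limit (the limit of > 200000 nM in this assay, at which 3 of the 3 values shown sit). The step that the limit leaves unreadable from compound 3 to compound 4 is therefore expected to leave compound 4 at that same edge. Compound 4 is estimated at 300000 nM in this assay, with an expected range from 150000 nM to 1000000 nM, and most likely it too will be reported only as a limit.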

Compound 4, half-maximal inhibitory concentration: 128000 nM
Compound 4: middle estimate off by 2.3-fold (0.37 log units), on the high side, outside the stated range (below it).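

In this assay, putting 2-phenylethenyl in place of 1-methyl-1H-indol-2-yl on the carbonyl carbon gives an at least 1.5-fold lower number from compound 3 to compound 4 (0.19 log units; that floor lies within the scatter), and putting hexyl in place of hydrogen on a saturated chain carbon gives an at least 1.5-fold lower number from compound 2 to compound 4 (0.19 log units; that floor lies within the scatter); each is only a floor, and neither establishes a real change on its own. Among these compounds, the same two changes made from compound 1 cannot be read, and almost the whole set sits at one edge of the read-out: the limit of > 200000 nM in this assay, at which 3 of the 4 values shown sit. This shows that the change can yield a measurable number on the core of compound 3, but it does not show that the change carries from one core to another, since the one bounded step has no readable partner on the core of compound 1 to be compared with.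

From the compounds shown here alone, how large the true gaps are, and whether the change would act alike on both cores, stays open. Also open, going by these compounds, is how the read-out would respond to a chain longer than that of compound 3, or to an amine or a carboxylic acid in place of the 2-phenylethenyl on the carbonyl carbon.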